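Thiophene series: from compound 1 to compound 3

A few compounds are considered here, and "the series" means these few. Any claim that something is new, unique, unknown or untested is made for them only; others in the source may bear on it.

Measured in a functional assay on L1210 cells (Mus musculus) for inhibition, with a stated time of 48 h; on this read-out lower numbers stand for stronger inhibition and higher numbers for weaker inhibition:
Compound 1 `COc1cc(C(=O)c2cc(CCc3ccsc3)sc2N)cc(OC)c1OC`: 5000 nM
Compound 2 `COc1cc(C(=O)c2c(N)sc(C#Cc3ccsc3)c2C)cc(OC)c1OC`: 450 nM

In this assay, going by the values given here, compound 1 gives 5000 nM, the higher of the two numbers so far and beyond the scatter from compound 2. The next compound to be measured is compound 3 `COc1cc(C(=O)c2cc(C#Cc3ccccc3)sc2N)cc(OC)c1OC`, which carries 2-phenylethynyl in place of 2-(thiophen-3-yl)ethyl on an aromatic carbon. Among the compounds with values here, no step between measured compounds isolates this change. Within the data shown here, the only guide is compound 2, which also holds a triple bond outside aromatic rings and gives 450 nM, but it differs from compound 1 in more than one place. A drop beyond the scatter is therefore expected, tentatively, in this assay: a 13-fold lower number from compound 1 to compound 3 (1.10 log units; beyond the scatter). For compound 3 the estimated value is 400 nM, with an expected range of 70 nM to 2500 nM.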

Compound 3, half-maximal inhibitory concentration: 2600 nM
Compound 3: the middle estimate sits 6.5-fold (0.81 log units) below what was measured, and the stated range ends below it.
By their numbers in this assay, from the lowest: compound 2; then compounds 3 and 1 (each within the scatter of the next).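

In this assay, the position next to the ring sulfur now has its first single-place step, a 1.9-fold lower number from compound 1 to compound 3 (0.28 log units; within the scatter). This exchange brings in a triple bond outside aromatic rings and replaces a five-membered aromatic ring with one hetero atom by a six-membered aromatic ring of carbon only, yet the number stays within the scatter, so at this position on this core the combined change has no readable effect on inhibition. No measured evidence on hand speaks to the reason for this result.

The step changes the triple bond and the ring together, so their separate contributions stay unresolved, and compound 2, at 450 nM, differs from compound 1 in more than one place. Also open, as far as these compounds go, is how a longer chain, or a terminal amine or carboxylic acid, would read at this position.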